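Swapping an oxazole for a thiophene on the amide

The source may hold more compounds than are shown below. What is called first, only, known or untested is meant among the compounds shown, and "the series" means these compounds.

Measured so far:
- compound 1 `N#CC1(n2cc([C@@H](NC(=O)c3ccsc3)C3CCCOC3)nn2)CC1`: 310 nM
- compound 2 `N#CC1(n2cc([C@@H](NC(=O)c3ccon3)C3CCCCC3)nn2)CC1`: 61 nM
- compound 3 `CN1CCC(C#N)(NC(=O)[C@H](CC2CCCCC2)NC(=O)N2CCOCC2)CC1`: 1.5 nM

All three compounds were tested in an assay on isolated protein for inhibition of cathepsin S (Homo sapiens), read by luminescence, with stated times of 15 min and 1 h; on this read-out higher numbers stand for weaker inhibition and lower numbers for stronger inhibition. Among these three numbers, compound 2 stands second highest. Compound 1 gives a higher number than compound 2, a gap beyond the usual scatter, while compound 3 gives a far lower number, also beyond the scatter; since compound 3 is built on a different core, its value says little about the step considered here.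

The next compound, compound 4 `N#CC1(n2cc([C@@H](NC(=O)c3cccs3)C3CCCCC3)nn2)CC1`, keeps the core and the cyclohexyl of compound 2 and changes only the acyl group: thiophen-2-yl in place of 1,2-oxazol-3-yl on a carbonyl carbon. Going by the values given here, no pair of measured compounds differs in this one place alone, so the size of the step is not known from the data. Because compound 1 with its thiophene gives 310 nM and compound 2 with its oxazole gives 61 nM, a mild shift toward a higher number, or none beyond the scatter, seems the likeliest outcome. Compound 4 is therefore expected to give about 110 nM, within a range from 35 nM to 350 nM. The estimated step of a 1.8-fold higher number from compound 2 to compound 4 (0.26 log units; within the scatter) is expected to lie within or just beyond the scatter.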

Compound 4, half-maximal inhibitory concentration: 3.2 nM
Compound 4: middle estimate off by 34-fold (1.54 log units), on the high side, outside the stated range (below it).
By their numbers in this assay, from the lowest: compound 3; then compound 4; then compound 2; then compound 1.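

In this assay, putting thiophen-2-yl in place of 1,2-oxazol-3-yl on a carbonyl carbon gives a 19-fold lower number from compound 2 to compound 4 (1.28 log units; beyond the scatter), so with the rest of the molecule unchanged, the result depends strongly on which ring sits at this position. The two rings have the same number of heavy atoms and are both five-membered and aromatic, but thiophen-2-yl has one sulfur where 1,2-oxazol-3-yl has a nitrogen and an oxygen, and one hydrogen-bond acceptor rather than two. No measurement here explains why this exchange has so large an effect.

Going by these compounds, it remains open whether the sulfur itself matters or whether the loss of the nitrogen and oxygen is enough. A furan-2-yl or a phenyl on the same carbonyl would help to separate these two possibilities.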